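The source may hold more compounds than are shown below. What is called first, only, known or untested is meant among the compounds shown, and "the series" means these compounds.

Measured compounds:
compound 1 `CCOc1ccc(F)cc1C(C)NC(=O)N(C)S(=O)(=O)c1ccccc1`, 11500 nM
compound 2 `COc1ccc(Br)cc1C(C)NC(=O)N(C)S(=O)(=O)c1ccc(C)cc1`, 19100 nM
compound 3 `CCOc1ccc(Br)cc1C(C)NC(=O)N(C)S(=O)(=O)c1ccc(C)cc1`, 28600 nM

In a functional assay on thoracic aorta (Rattus norvegicus, strain Wistar), with a stated time of 15 min (on this read-out higher numbers stand for an effect only at larger amounts of compound and lower numbers for an effect already at smaller amounts), compound 3 gives 28600 nM, the highest of the three numbers. Within the data shown here, compound 2 sits closest, and the one step that changes a single place, a 1.5-fold higher number from compound 2 to compound 3 (0.18 log units; within the scatter), lies within the scatter. Compound 1 is furthest from compound 3, its number lower by a margin beyond the scatter, but compound 1 and compound 3 differ in two places at once, so that gap cannot be assigned to either change.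

Compound 4 `CCOc1ccc(Br)cc1C(C)NC(=O)N(C)S(=O)(=O)c1ccccc1` is not yet measured. Against compound 3 the change is hydrogen in place of methyl on an aromatic carbon. Among the measured compounds shown here, no measured step bears directly on this change: the only single-place step known here concerns the chain on the ring oxygen, not the aromatic methyl. Compound 1, which carries the unsubstituted ring, gives the lowest number, but its halogen also differs, so this is not evidence for the step alone. The expectation is therefore a step of a 1.4-fold lower number from compound 3 to compound 4 (0.16 log units; within the scatter) of no more than the scatter, in either direction.

Compound 4 is estimated at 20000 nM, with a range of 8000 nM to 50000 nM.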

Compound 4, half-maximal effective concentration: 19800 nM
The estimate for compound 4 lay 1.0-fold (0.00 log units) above the measured number, and the stated range covers the measured number.
By their numbers in this assay, from the lowest: compounds 1, 2, 4 and 3 (each within the scatter of the next, the first and the last beyond it).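

In this assay the change from 4-methylphenyl to phenyl, on an aromatic carbon para to a large group, can now be read on its own: a 1.4-fold lower number from compound 3 to compound 4 (0.16 log units; within the scatter) shows that the methyl at this position can give way to hydrogen without a move beyond the scatter. Among these compounds, the halogen on the other aromatic ring can also be read alone for the first time, and a 1.7-fold higher number from compound 1 to compound 4 (0.24 log units; within the scatter) shows that bromo in place of fluoro likewise stays within the scatter, so neither of these two single changes separates its pair of compounds. No accompanying data explain either step.

From the compounds shown here alone, the substituent at the para carbon is so far limited to methyl and hydrogen, so it remains open whether a methoxy group, a carboxylic acid or an amine at that place would leave the number inside the scatter. On the other ring, chloro is open as a third halogen, and no single change shown here yet moves the number beyond the scatter.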